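The source may report more compounds than this note shows. Statements on the series, on what has been measured and on what is new or still open speak of the compounds shown alone.

Measured so far:
compound 1 `C=C1[C@@H](OC(C)=O)C[C@@H]2[C@](C)(COC=O)[C@H](OC(C)=O)CC[C@@]2(C)[C@@H]1C[C@@H](Nc1ccccc1C(=O)O)C1=CCOC1=O`: 42500 nM
compound 2 `C=C1CC[C@@H]2[C@](C)(CO[Si](C)(C)C(C)(C)C)[C@H](OC(C)=O)CC[C@@]2(C)[C@@H]1C/C=C1/C(=O)OC[C@H]1OC(C)=O`: 5050 nM

Both numbers come from a functional assay on KB cells (Homo sapiens) for cytotoxicity, read by sulforhodamine B assay; on this read-out higher numbers stand for weaker inhibition and lower numbers for stronger inhibition. Compound 1 stands highest of the two; compound 2 gives a lower number, and the gap between them lies beyond the usual scatter of repeated measurements. Compound 3 `C=C1[C@@H](OC(C)=O)C[C@@H]2[C@](C)(COC=O)[C@H](OC(C)=O)CC[C@@]2(C)[C@@H]1C[C@@H](Nc1cccc2ccccc12)C1=CCOC1=O` differs from compound 1 in one place: naphthalen-1-yl in place of 2-carboxyphenyl on an amine nitrogen. Among the measured compounds shown here, no measured pair shows this change, so its size is not known from the data; a moderate step toward a lower number is expected, a 3.0-fold lower number from compound 1 to compound 3 (0.48 log units; beyond the scatter). For compound 3 in this assay the estimate is 14000 nM, with a range from 4000 nM to 50000 nM.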

Compound 3, half-maximal inhibitory concentration: 32300 nM
Compound 3: middle estimate off by 2.3-fold (0.36 log units), on the low side; measured number inside the range.
By their numbers in this assay, from the lowest: compound 2; then compounds 3 and 1 (each within the scatter of the next).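

Putting naphthalen-1-yl in place of 2-carboxyphenyl on the amine nitrogen gives a 1.3-fold lower number from compound 1 to compound 3 (0.12 log units; within the scatter) in this assay. On this read-out the two groups cannot be told apart, even though one has a hydrogen-bond donor and acceptor and the other has neither. No available evidence bears on why this is so. Still open, on these data alone, is whether a plain phenyl, a benzyl or a short alkyl chain on this nitrogen would give a number clearly different from these two. As far as these compounds go, the effect of an amide in place of the amine is also open.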